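The source may report more compounds than this note shows. Statements on the series, on what has been measured and on what is new or still open speak of the compounds shown alone.

Measured compounds in an ADME assay on microsomes from liver (Homo sapiens) for metabolic stability, read by LC-MS, with a stated time of 15 min, tested at 1 uM, in the presence of a further agent that is not named here; on this read-out higher numbers stand for a more stable compound and lower numbers for a less stable compound:
Compound 1 `CCc1nc(N)nc2c1c(-c1ccc3oc(N)nc3c1)nn2C(C)C` gives 93%.
Compound 2 `CC(C)n1nc(-c2ccc3oc(N)nc3c2)c2c(C#N)nc(N)nc21` gives > 95%, which is a limit of the assay and not a number.
Compound 3 `CC(C)n1nc(-c2ccc3oc(N)nc3c2)c2c(=O)[nH]c(N)nc21` gives > 95%, again a limit of the assay rather than a number.

Compound 3 therefore stands at the upper end of what this assay reports, and only a limit is known for it; (the limit of > 95% in this assay, at which 2 of the 3 values shown sit), so the measured range here is narrow.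

Compound 4 `Cc1nc2c(c(-c3ccc4oc(N)nc4c3)nn2C(C)C)c(=O)[nH]1` differs from compound 3 by methyl in place of amino on an aromatic carbon. Going by the values given here, none of the measured steps covers exactly this exchange. Among the compounds with values here, the only measured single-point step, a number at least 2 percentage points higher from compound 1 to compound 2 (that floor lies within the scatter), concerns a different pair of groups on a different carbon of the shared core and is itself no larger than the scatter. Across compound 1, compound 2 and compound 3 the numbers remain high throughout, so no change beyond the scatter is expected from the exchange of amino for methyl at this position.

Compound 4 is accordingly expected to read 90% in this assay, with a range from 75% to 98%. The step of a number at least 5 percentage points lower from compound 3 to compound 4 (that floor lies within the scatter) that this estimate implies is expected to stay within the scatter, with some chance that the assay again returns only its limit.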

Compound 4, percent of the compound remaining: > 95%
Compound 4: only a limit was reported; the forecaster's own chance of this, stated with the estimate: 40%; middle value at least 5 percentage points away from the limit.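

In this assay compound 3 gives > 95%, which is a limit and not a number. Going by these compounds alone, compound 4 gives > 95%, again a limit, so no step between compound 3 and compound 4 can be read: the limit of > 95% in this assay, at which 3 of the 4 values shown sit. The compounds shown leave open what size of change, if any, methyl in place of amino on an aromatic carbon brings in this read-out.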